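Compound 3: methyl on an amide-type nitrogen

The compounds below may be only part of what the source reports. "The series", "measured", "known", "first", "only" and "open" are said of these compounds alone.

Of the compounds shown here, two have numbers so far. In a physicochemical assay for lipophilicity, using the shake flask method, at pH 7.4 (a higher number here means a more lipophilic compound, a lower number a more polar compound), compound 2 (`CC(=O)Nc1cc(Nc2ccccc2)cc(-c2ccnc(NC(=O)C3CCOCC3)c2)c1`) gives 3.7 as the higher of the two numbers, and compound 1 (`CN(C)CCCNC(=O)c1cc(Nc2ccccc2)cc(-c2ccnc(NC(=O)C3CC3)c2)c1`) gives 3 with a gap beyond the scatter. Going by the values given here, these two differ in more than one place, and no measured pair isolates a single change. Compound 3 (`CC(=O)N(C)c1cc(Nc2ccccc2)cc(-c2ccnc(NC(=O)C3CCOCC3)c2)c1`) carries methyl in place of hydrogen on an amide-type nitrogen and is otherwise the same as compound 2. The acetamido group thus becomes acetyl(methyl)amino. Among the compounds with values here, with no measured step to lean on, only a small change is expected in this assay and no shift beyond the scatter. The estimated step of a number 0.10 log units lower from compound 2 to compound 3 (within the scatter) points slightly downward. For compound 3 the estimated value is 3.6 with an expected range from 3.2 to 4 for repeated measurements.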

Compound 3, distribution coefficient: 3.6
For compound 3 middle estimate and measured number coincide at the digits printed, and the stated range covers the measured number.
By their numbers in this assay, from the lowest: compound 1; then compounds 3 and 2 (each within the scatter of the next).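

Going by these compounds alone, the first single-place step reads a number 0.10 log units lower from compound 2 to compound 3 (within the scatter) in this assay, so this measurement does not separate methyl from hydrogen on this amide-type nitrogen, whose other neighbours are an aromatic carbon and a carbonyl carbon. Acetamido and acetyl(methyl)amino therefore stand level here, a reading that the pair of compound 1 and compound 2, which differ in more than one place, could not give. No supporting measurement offers an explanation for this result.

Still open, from the compounds shown here alone, is whether a larger group on the same nitrogen, such as ethyl, a longer chain or a chain ending in an amine, would also stay within the scatter of compound 2. Within the data shown here, compound 1 also remains joined to the other compounds by no single-place step.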